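A few compounds are considered here, and "the series" means these few. Any claim that something is new, unique, unknown or untested is made for them only; others in the source may bear on it.

Measured compounds: compound 1 `OCc1cccc(C2=NC(c3ccc(F)cc3)(c3ccc(F)cc3)CN2)c1`, compound 2 `CN(C)c1cccc(C2=NC(c3ccc(F)cc3)(c3ccc(F)cc3)CN2)c1`, compound 3 `Fc1ccc(C2(c3ccc(F)cc3)CNC(c3ccsc3)=N2)cc1`.

In an assay on LM cells for displacement of a labelled ligand from Neuropeptide Y receptor type 5 (Homo sapiens) (on this read-out higher numbers stand for weaker inhibition and lower numbers for stronger inhibition), compound 1 gives 59 nM. For compound 2 this assay reports only a limit, > 1000 nM. In this assay compound 3 gives 93 nM, the higher of the two numbers, with a 1.6-fold higher number from compound 1 to compound 3 (0.20 log units; within the scatter).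

Compound 4 `Fc1ccc(C2(c3ccc(F)cc3)CNC(c3ccncc3)=N2)cc1` carries pyridin-4-yl in place of thiophen-3-yl on a carbon with a double bond to nitrogen. Two steps change the same carbon: a 1.6-fold higher number from compound 1 to compound 3 (0.20 log units; within the scatter) stayed small, whereas an at least 10-fold lower number from compound 2 to compound 3 (1.03 log units; beyond the scatter) was large, so the group on this carbon can matter greatly. Pyridin-4-yl, like thiophen-3-yl, carries one acceptor and no donor, so a step of a 1.6-fold higher number from compound 3 to compound 4 (0.21 log units; within the scatter) is expected. Compound 4 is estimated at 150 nM, between 40 nM and 600 nM.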

Compound 4, half-maximal inhibitory concentration: 160 nM
For compound 4 the middle estimate is 1.1-fold (0.03 log units) below the measured one; measured number inside the range.
By their numbers in this assay, from the lowest: compounds 1, 3 and 4 (each within the scatter of the next, the first and the last beyond it). At a limit, above all of these: compound 2.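

In this assay, a six-membered aromatic ring with nitrogen on this carbon reads like the five-membered ring with sulfur: a 1.7-fold higher number from compound 3 to compound 4 (0.24 log units; within the scatter). Measured against the 3-(hydroxymethyl)phenyl group, however, pyridin-4-yl gives a step beyond the scatter, which thiophen-3-yl did not: a 2.7-fold higher number from compound 1 to compound 4 (0.43 log units; beyond the scatter). The step of an at least 6.2-fold lower number from compound 2 to compound 4 (0.79 log units; beyond the scatter) starts from a limit of the assay, so it is only a bound: the limit of > 1000 nM in this assay, at which 1 of the 4 values shown sits.

The compounds shown leave open how a plain phenyl or a pyridin-3-yl ring would read on this carbon. They also leave open whether a 3-aminophenyl group would follow the hydroxymethyl or the dimethylamino compound.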